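Opening a closed limit by swapping one ring group

The source may hold more compounds than are shown below. What is called first, only, known or untested is meant among the compounds shown, and "the series" means these compounds.

Compound 1 `O=C(NCc1ccc(S(=O)(=O)c2ccccc2)cc1)c1cc2ncccc2s1`: > 10000 nM
Compound 2 `O=C(NCc1ccc(S(=O)(=O)c2cccc(C(F)(F)F)c2)cc1)c1cc2cnccc2[nH]1`: 3 nM
Compound 3 `Cn1c(C(=O)NCc2ccc(S(=O)(=O)c3ccccc3)cc2)cc2ccncc21`: > 10000 nM

In a functional assay on A2780 cells (Homo sapiens) for inhibition, read by sulforhodamine B assay, with a stated time of 72 h (on this read-out lower numbers stand for stronger inhibition and higher numbers for weaker inhibition), compound 1 gives > 10000 nM, which is a limit of the assay and not a number. Compound 3 gives > 10000 nM, which is also a limit. Compound 1 therefore stands at the limit of > 10000 nM in this assay, at which 2 of the 3 values shown sit.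

Compound 4 `O=C(NCc1ccc(S(=O)(=O)c2ccccc2)cc1)c1c[nH]c2ccncc12` has not yet been measured. It keeps the rest of compound 1 and changes only the group on the carbonyl carbon: a group of 9 heavy atoms (7 carbon, 2 nitrogen; one five-membered aromatic ring with 1 hetero atom, one six-membered aromatic ring with 1 hetero atom) in place of a group of 9 heavy atoms (7 carbon, 1 nitrogen, 1 sulfur; one five-membered aromatic ring with 1 hetero atom, one six-membered aromatic ring with 1 hetero atom), on a carbonyl carbon.

For the measured compounds named here, no measured pair shows this change directly. Compound 2 gives 3 nM, so strong inhibition does occur among these compounds, and a gain for compound 4 is expected on that basis alone. The gain is expected to be moderate, and compound 4 may well remain at the limit. The estimated at least 5.0-fold lower number from compound 1 to compound 4 (0.69 log units; beyond the scatter) points toward stronger inhibition. For compound 4 the expected value is 2000 nM, within an estimated range of 100 nM to 10000 nM.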

Compound 4, half-maximal inhibitory concentration: 2100 nM
Compound 4: the middle estimate sits 1.1-fold (0.02 log units) below what was measured; low and high end bracket the measured number.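

Changing only the group on the carbonyl carbon is enough to bring a measurable number out of the limit: in this assay, the change gives an at least 4.7-fold lower number from compound 1 to compound 4 (0.67 log units; beyond the scatter). The group that enters carries 1 hydrogen-bond donor and the group that leaves carries 0 hydrogen-bond donors, but a single step cannot show whether that difference in count is what matters. The full size of the step cannot be stated because compound 1 gives only a limit and not a number: the limit of > 10000 nM in this assay, at which 2 of the 4 values shown sit.

Compound 2, at 3 nM, differs from compound 4 in more than one place, so these compounds cannot say which of its differences accounts for that value. On these data alone, what a simple amine or a carboxylic acid would do in place of this group on the carbonyl carbon also remains open.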